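Sulfonamide series: 3-chlorophenyl for 3,4-difluorophenyl

This account rests on a few compounds, and the source may have more. Where it says the series, first, only, none or still open, it means among the compounds named here.

Compound 1 (`CCCCCCCc1ccc(NS(=O)(=O)c2ccc(N3CCNC3=O)cc2)cc1`) > 1000 nM
Compound 2 (`O=C1NCCN1c1ccc(S(=O)(=O)Nc2ccc(F)c(F)c2)cc1`) 350 nM
Compound 3 (`O=C1NCCN1c1ccc(S(=O)(=O)Nc2ccc3c(c2)CCC3)cc1`) 190 nM

In a functional assay on HT-29 cells (Homo sapiens) for antiproliferative activity, read by sulforhodamine B assay, with a stated time of 48 h (on this read-out higher numbers stand for weaker inhibition and lower numbers for stronger inhibition), the entry for compound 1 is a limit and not a number, given as > 1000 nM in the list. Compound 2 gives 350 nM and compound 3 gives 190 nM and these two values lie within the scatter of each other, so neither can be ranked ahead.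

Compound 4 (`O=C1NCCN1c1ccc(S(=O)(=O)Nc2cccc(Cl)c2)cc1`) has not yet been measured. It carries 3-chlorophenyl in place of 3,4-difluorophenyl on a sulfonamide nitrogen. Among the compounds with values here, no measured pair shows a swap of this kind, so the expectation starts from compound 2 at 350 nM and assumes no shift beyond the scatter in this assay for this change. The expected size is an estimated step of a 1.2-fold lower number from compound 2 to compound 4 (0.07 log units; within the scatter) that stays within the scatter. Compound 4 is expected at 300 nM with an estimated range of 120 nM to 800 nM in this read-out.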

Compound 4, half-maximal inhibitory concentration: 55 nM
For compound 4 the middle estimate is 5.5-fold (0.74 log units) above the measured one; the whole stated range lies above it.
By their numbers in this assay, from the lowest: compound 4; then compounds 3 and 2 (each within the scatter of the next). At a limit, above all of these: compound 1.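

In this assay, within the data shown here, the swap to 3-chlorophenyl gives a 6.4-fold lower number from compound 2 to compound 4 (0.80 log units; beyond the scatter), the first step that can be read, and it shows that the aryl group on a sulfonamide nitrogen can move this number beyond the scatter. Both groups are a six-membered aromatic ring of carbon only, with no hydrogen-bond donors or acceptors and no net charge, so these counts do not separate them and the step goes with the change in halogens on the ring. Nothing measured here bears on why the number falls.

From the compounds shown here alone, whether the step depends on chlorine itself or on the ring carrying one halogen instead of two stays open. Also open, going by these compounds, is how a methoxy group, an amine or a carboxylic acid in place of the chlorine would read.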